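The source may hold more compounds than are shown below. What is called first, only, known or untested is meant among the compounds shown, and "the series" means these compounds.

Measured in a functional assay on A549 cells (Homo sapiens) for antiproliferative activity, read by MTT assay, with a stated time of 48 h; a higher number here means a weaker inhibitor, a lower number a stronger inhibitor:
- Compound 1 `O=C(/C=C/c1ccccc1)Nc1nnc(-c2ccccc2)s1`: 1.75 ug/mL
- Compound 2 `O=C(/C=C/c1ccccc1)Nc1nnc(-c2ccc(Br)cc2)s1`: 2.18 ug/mL

Compound 2, at 2.18 ug/mL, stands within the scatter of compound 1, so the two cannot be separated in this assay. Compound 3 `O=C(/C=C/c1ccccc1)Nc1nnc(-c2ccc(Cl)cc2)s1` has chloro in place of bromo on an aromatic carbon. For the measured compounds named here, only one measured step bears on this: a 1.2-fold higher number from compound 1 to compound 2 (0.10 log units; within the scatter), which put bromo in place of hydrogen on an aromatic carbon and lies within the scatter. No step beyond the scatter is therefore expected, in either direction. The estimated 1.1-fold lower number from compound 2 to compound 3 (0.04 log units; within the scatter) is expected to remain within the scatter. For compound 3 the estimated value is 2 ug/mL, with an expected range from 1.1 ug/mL to 3.6 ug/mL.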

Compound 3, half-maximal inhibitory concentration: 2.02 ug/mL
The estimate for compound 3 lay 1.0-fold (0.00 log units) below the measured number; measured number inside the range.
By their numbers in this assay, from the lowest: compounds 1, 3 and 2 (each within the scatter of the next).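

In this assay the change from 4-bromophenyl to 4-chlorophenyl gives a 1.1-fold lower number from compound 2 to compound 3 (0.03 log units; within the scatter) and chloro in place of hydrogen gives a 1.2-fold higher number from compound 1 to compound 3 (0.06 log units; within the scatter) on the same core. A second halogen at this place, on an aromatic carbon para to a large group, thus also stays within the scatter, where earlier only bromo had been seen. No evidence bears on these values. The compounds shown leave open whether an amine, a methoxy group or a carboxylic acid at this place would move the number beyond the scatter. Changes elsewhere on the shared core also remain open.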